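The compounds below may be only part of what the source reports. "The series", "measured", "known", "first", "only" and "open" are said of these compounds alone.

Measured compounds, with their numbers in an assay on Cerebral cortex for displacement of a labelled ligand from adenosine receptor A1 (Bos taurus); a lower number here means a stronger inhibitor, a higher number a weaker inhibitor:
compound 1 `CCCCNc1nc(-c2ccccc2)nc2c1nnn2Cc1ccccc1F` — 4.3 nM
compound 2 `CCCCNc1nc(-c2ccccc2)nc2c1nnn2Cc1ccccc1C(F)(F)F` — 6.5 nM
compound 3 `Fc1ccccc1Cn1nnc2c(NC3CCCCC3)nc(-c3ccccc3)nc21` — 1.15 nM

Compound 3 gives the lowest number of the three in this assay; the step from compound 1 is a 3.7-fold lower number from compound 1 to compound 3 (0.57 log units; beyond the scatter), and the change behind it is cyclohexyl in place of butyl on a nitrogen on an aromatic ring. The other step, a 1.5-fold higher number from compound 1 to compound 2 (0.18 log units; within the scatter), goes with the change trifluoromethyl in place of fluoro on an aromatic carbon and stays within the scatter.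

Compound 4 `FC(F)(F)c1ccccc1Cn1nnc2c(NC3CCCCC3)nc(-c3ccccc3)nc21` is not yet measured. It differs from compound 3 by trifluoromethyl in place of fluoro on an aromatic carbon, the same change that takes compound 1 to compound 2, at the same place on the same kind of ring. Since compound 1 to compound 2 moved only by a 1.5-fold higher number from compound 1 to compound 2 (0.18 log units; within the scatter), the step from compound 3 to compound 4 is expected to be about as small, a 1.5-fold higher number from compound 3 to compound 4 (0.17 log units; within the scatter). Compound 4 is therefore estimated at 1.7 nM, within 0.7 nM to 4 nM.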

Compound 4, inhibition constant: 6.8 nM
Beside the measured number, compound 4's estimate is 4.0-fold (0.60 log units) below it, outside the stated range (above it).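

In this assay, trifluoromethyl in place of fluoro gives a 5.9-fold higher number from compound 3 to compound 4 (0.77 log units; beyond the scatter), so this change does not carry over unchanged from the butyl compounds to the cyclohexyl compounds: the same change on two cores in this assay, a 1.5-fold higher number (0.18 log units; within the scatter) from compound 1 to compound 2 and a 5.9-fold higher number (0.77 log units; beyond the scatter) from compound 3 to compound 4, 3.9-fold (0.59 log units) apart, beyond the scatter of two such steps

With trifluoromethyl present, cyclohexyl in place of butyl gives a 1.0-fold higher number from compound 2 to compound 4 (0.02 log units; within the scatter), so the two changes do not add independently across these four compounds: the same change on two cores in this assay, a 3.7-fold lower number (0.57 log units; beyond the scatter) from compound 1 to compound 3 and a 1.0-fold higher number (0.02 log units; within the scatter) from compound 2 to compound 4, 3.9-fold (0.59 log units) apart, beyond the scatter of two such steps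

This shows that the size of the step depends on the partner group in this set; it does not show why, or how the step would run with any other group on the nitrogen.

Open, as far as these compounds go, is whether the same dependence appears with a chloro or methoxy group in place of fluoro. Also open, from the compounds shown here alone, is how a cyclopentyl group or a longer chain on the nitrogen would behave.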